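Chloro on the aromatic ring of compound 1

The compounds below may be only part of what the source reports. "The series", "measured", "known", "first", "only" and "open" are said of these compounds alone.

Compound 1 `COC(=O)C1=C(C)NC(=O)NC1c1ccccc1` carries a six-membered aromatic ring of carbon only on a saturated ring carbon of the shared core. In an assay for inhibition of beta-glucuronidase (Bos taurus), read by spectrophotometry, with a stated time of 30 min (a lower number here means a stronger inhibitor, a higher number a weaker inhibitor), compound 1 gives "not active" (no number reported), so no number stands for it and it cannot be ranked against the other compounds. Two further compounds on the same core do have numbers: compound 2 `COC(=O)C1=C(C)NC(=O)NC1CC(C)C` gives 55200 nM in this assay, and compound 3 `COC(=O)C1=C(C)NC(=O)NC1c1cccs1` gives 18200 nM. Going by the values given here, the one measured step, a 3.0-fold lower number from compound 2 to compound 3 (0.48 log units; beyond the scatter), exchanges the group on the saturated ring carbon and lowers the number by a modest amount. Compound 4 `COC(=O)C1=C(C)NC(=O)NC1c1ccc(Cl)cc1` differs from compound 1 by chloro in place of hydrogen on an aromatic carbon, para to a large group. Among the compounds with values here, no measured step touches a substituent on the aromatic ring itself, so the step from compound 2 to compound 3 bears on the present change only indirectly: it shows that alterations at the group on the saturated ring carbon shift this assay by a modest amount, and nothing larger has been seen. With compound 1 reported without a number, no direction can be set for compound 4 in this assay beyond noting that the measured compounds sit at high concentrations. Compound 4 is expected to give about 60000 nM in this assay, within 15000 nM to 250000 nM, and a report of only a limit for compound 4 remains quite possible.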

Compound 4, half-maximal inhibitory concentration: 34200 nM
Compound 4: the middle estimate sits 1.8-fold (0.24 log units) above what was measured; the range from low to high includes it.
By their numbers in this assay, from the lowest: compounds 3, 4 and 2 (each within the scatter of the next, the first and the last beyond it).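

Going by these compounds alone, compound 1 gives "not active" (no number reported) and compound 4 gives 34200 nM, so no step between them can be read. No available evidence bears on this result. The compounds shown leave open what chloro in place of hydrogen on the aromatic carbon does to the number.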